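This account rests on a few compounds, and the source may have more. Where it says the series, first, only, none or still open, it means among the compounds named here.

Measured in an ADME assay on microsomes from liver (Homo sapiens) for metabolic stability, read by LC-MS, with NADPH named in the record, with a stated time of 60 min, tested at 1 uM, in the absence of a further agent; on this read-out lower numbers stand for a less stable compound and higher numbers for a more stable compound:
- Compound 1 `COc1ccc(-c2c(C)nc3c(N4CC[C@@H](NC(C)=O)C4)cc(C)nn23)cc1OC`: > 95%, a limit
- Compound 2 `COc1ccc(-c2c(C)nc3c(N4CC[C@@H](NC(C)=O)C4)cc(C)nn23)cn1`: > 95%, a limit
- Compound 3 `CC(=O)N[C@@H]1CCN(c2cc(C)nn3c(-c4ccco4)c(C)nc23)C1`: > 95%, a limit

Compound 3 has no exact number, only the limit > 95%. The same is true across the whole set: the limit of > 95% in this assay, at which 3 of the 3 values shown sit.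

Compound 4 `CC(=O)N[C@@H]1CCN(c2cc(C)nn3c(-c4ccc5cc[nH]c5c4)c(C)nc23)C1` keeps the shared core and places 1H-indol-6-yl in place of furan-2-yl on an aromatic carbon.

Three measured changes concern this same place: a step that the two limits leave unreadable from compound 1 to compound 2, a step that the two limits leave unreadable from compound 1 to compound 3 and a step that the two limits leave unreadable from compound 2 to compound 3. None of them gives a size, so they offer no measured effect to carry over. They show only that 3,4-dimethoxyphenyl, 6-methoxypyridin-3-yl and furan-2-yl all gave the same limit in this assay. From the compounds shown here alone, on that basis, no step beyond the usual scatter is expected, although 1H-indol-6-yl is untested here and the range must stay wide, mainly downward. The expected change is a number at least 5 percentage points lower from compound 3 to compound 4 (that floor lies within the scatter). For compound 4 the estimate is 90%, with an expected range from 68% to 100%.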

Compound 4, percent of the compound remaining: > 95%
Compound 4: only a limit was reported (the forecaster's own chance of this, stated with the estimate: 45%); middle value at least 5 percentage points from the limit.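

For the compounds shown here, compound 4 gives only a limit in this assay, so no step between it and compound 1, compound 2 or compound 3 can be read, because the values all stop at the same point: the limit of > 95% in this assay, at which 4 of the 4 values shown sit. From the compounds shown here alone, how far these four compounds truly differ in stability remains open.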